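The compounds below may be only part of what the source reports. "The series", "measured", "known", "first", "only" and "open" are said of these compounds alone.

For the measured compounds named here, compound 1 `O=C1c2c[n+]([O-])c3ccccc3c2C(=O)c2c1c1ccccc1n2Cc1cn(C[C@@H](O)CO)nn1` gives 2030 nM in a toxicity assay on HEK-293T cells (Homo sapiens) for cytotoxicity, read by MTT assay, with a stated time of 72 h (a higher number here means a weaker inhibitor, a lower number a stronger inhibitor), the highest of the three numbers measured so far. Compound 2 `O=C1c2c[n+]([O-])c3ccccc3c2C(=O)c2[nH]c3ccccc3c21` gives 890 nM and compound 3 `CN(C)CCCCn1c2c(c3ccccc31)C(=O)c1c[n+]([O-])c3ccccc3c1C2=O` gives 520 nM; the steps are a 2.3-fold lower number from compound 1 to compound 2 (0.36 log units; beyond the scatter) and a 3.9-fold lower number from compound 1 to compound 3 (0.59 log units; beyond the scatter), while a 1.7-fold lower number from compound 2 to compound 3 (0.23 log units; within the scatter). Compound 4 `CC1(C)OC[C@H](Cn2cc(Cn3c4c(c5ccccc53)C(=O)c3c[n+]([O-])c5ccccc5c3C4=O)nn2)O1` differs from compound 1 by 2,2-dimethyl-1,3-dioxolan-4-yl in place of 1,2-dihydroxyethyl on a saturated chain carbon bound to an aromatic nitrogen. Neither measured step bears directly on this change: each removes or exchanges the whole substituent on the aromatic nitrogen, whereas in compound 4 the triazole is kept and only the 2,3-dihydroxypropyl is exchanged for (2,2-dimethyl-1,3-dioxolan-4-yl)methyl. Both measured steps did lower the number modestly, so a small lowering or none beyond the scatter is expected, a 1.6-fold lower number from compound 1 to compound 4 (0.19 log units; within the scatter). Compound 4 is estimated at 1300 nM, within 500 nM to 3200 nM.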

Compound 4, half-maximal inhibitory concentration: 100 nM
The estimate for compound 4 lay 13-fold (1.11 log units) above the measured number; measured number outside the range, below it.
By their numbers in this assay, from the lowest: compound 4; then compounds 3 and 2 (each within the scatter of the next); then compound 1.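

In this assay, a 20-fold lower number from compound 1 to compound 4 (1.31 log units; beyond the scatter) is a large step, larger than either earlier step from compound 1, although the triazole stays in place. The outer part of this substituent therefore matters in its own right: 2,3-dihydroxypropyl gives way to (2,2-dimethyl-1,3-dioxolan-4-yl)methyl, which has no hydrogen-bond donors and one five-membered non-aromatic ring. No evidence here accounts for the step. Going by these compounds, it remains open whether the free hydroxyls or the ring with its two methyl groups carry the change. Methoxy groups on an open chain would separate these two readings.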